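The compounds below may be only part of what the source reports. "The series", "measured", "known", "first", "only" and "open" are said of these compounds alone.

Three compounds built on one shared core were measured in an in vitro functional assay on cells for agonist activity at Bombesin receptor subtype-3 (Homo sapiens), read by luminescence and calcium flux; on this read-out higher numbers stand for an effect only at larger amounts of compound and lower numbers for an effect already at smaller amounts. Compound 1 `O=C(O)c1ccccc1-c1ccc(CCc2ncc(CC3CCCCC3)[nH]2)cc1` gives 41 nM. Compound 2 `O=C(O)c1ccccc1-c1ccc(CCc2ncc(CC3CCCC3)[nH]2)cc1` gives 133 nM, and compound 3 `CC(C)CCc1cnc(CCc2ccc(-c3ccccc3C(=O)O)cc2)[nH]1` gives 119 nM. Compound 3 thus stands second highest of the three numbers, with compound 2 nearest to it and compound 1 furthest away. The steps among the three are all modest or smaller: a 3.2-fold higher number from compound 1 to compound 2 (0.51 log units; beyond the scatter) and a 2.9-fold higher number from compound 1 to compound 3 (0.46 log units; beyond the scatter), whereas a 1.1-fold lower number from compound 2 to compound 3 (0.05 log units; within the scatter).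

Compound 4 `O=C(O)c1ccccc1-c1ccc(CCc2ncc(-c3ccccc3)[nH]2)cc1` has not yet been measured. Its change from compound 3 is phenyl in place of isopentyl on an aromatic carbon. Within the data shown here, none of the measured steps exchanges a saturated group for an aromatic ring at this position; each of them only swaps one saturated group for another, and none moves the number far. The closest guide is that the two smaller saturated groups of compound 2 and compound 3 both give higher numbers than compound 1, as a 3.2-fold higher number from compound 1 to compound 2 (0.51 log units; beyond the scatter) and a 2.9-fold higher number from compound 1 to compound 3 (0.46 log units; beyond the scatter) show. On that basis a modest step in this assay is expected, in either direction, and the uncertainty is wide.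

Compound 4 is estimated at 150 nM, with a range from 40 nM to 600 nM. The step this estimate implies is a 1.3-fold higher number from compound 3 to compound 4 (0.10 log units; within the scatter).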

Compound 4, half-maximal effective concentration: 4950 nM
Beside the measured number, compound 4's estimate is 33-fold (1.52 log units) below it; measured number above the stated range.
By their numbers in this assay, from the lowest: compound 1; then compounds 3 and 2 (each within the scatter of the next); then compound 4.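

At this aromatic carbon next to the ring nitrogen, the saturated groups had stayed within modest steps of one another, but in this assay phenyl sets compound 4 far apart from all of them, with large steps from each: isopentyl (a 42-fold higher number from compound 3 to compound 4 (1.62 log units; beyond the scatter)), cyclopentylmethyl (a 37-fold higher number from compound 2 to compound 4 (1.57 log units; beyond the scatter)) and cyclohexylmethyl (a 120-fold higher number from compound 1 to compound 4 (2.08 log units; beyond the scatter)). The position therefore accepts exchanges among these three saturated groups with little change in the number, yet it does not treat every carbon-only group alike, since phenyl, like isopentyl, carries no hydrogen-bond donors or acceptors and no net charge. Nothing available accounts for this large shift.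

Phenyl differs from the three saturated groups in two ways at once, as it brings an aromatic ring and also has no saturated chain carbon between its ring and the aromatic carbon of the core, so the compounds shown cannot say which of these matters. On these data alone, a benzyl group, or a cyclohexyl ring bound directly to that carbon, would separate the two, and whether a pyridyl ring behaves like phenyl also stays open.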